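This account rests on a few compounds, and the source may have more. Where it says the series, first, only, none or still open, it means among the compounds named here.

Compound 1 `Cc1nn(C)cc1Nc1nc(N)c2c(C#N)c(N3CCC[C@H]3C)n(C)c2n1`: 30 nM
Compound 2 `C[C@@H]1CCCN1c1c(C#N)c2c(N)nc(Nc3cn(C)nc3C(F)(F)F)nc2n1C`: 358 nM
Compound 3 `C[C@@H]1CCCN1c1c(C#N)c2c(N)ncnc2n1C`: 11 nM

These three compounds were tested in an assay on isolated protein for inhibition of Leucine-rich repeat serine/threonine-protein kinase 2 variant G2019S (Homo sapiens), read by TR-FRET and LanthaScreen, with stated times of 50 min and 30 min, in the presence of a further agent that is not named here; on this read-out lower numbers stand for stronger inhibition and higher numbers for weaker inhibition. Compound 3 stands at the lowest number of the three: compound 1 sits a step of a 2.7-fold lower number from compound 1 to compound 3 (0.44 log units; beyond the scatter) away from it, and compound 2 lies still further off. Compound 4 `Cc1c(Nc2nc(N)c3c(C#N)c(N4CCC[C@H]4C)n(C)c3n2)cnn1C` differs from compound 3 by (1,5-dimethyl-1H-pyrazol-4-yl)amino in place of hydrogen on an aromatic carbon. Among the measured compounds shown here, the one measured step that bears on this, a 2.7-fold lower number from compound 1 to compound 3 (0.44 log units; beyond the scatter), went the other way with a closely related group, so reversing it points to a modest rise in the number. Beyond that, a 12-fold higher number from compound 1 to compound 2 (1.08 log units; beyond the scatter) shows that changing the group on the pyrazole can shift the result a lot, which widens the uncertainty. For compound 4 the expected step is a 3.6-fold higher number from compound 3 to compound 4 (0.56 log units; beyond the scatter), giving an estimate of 40 nM with a range from 10 nM to 160 nM.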

Compound 4, half-maximal inhibitory concentration: 43 nM
Compound 4: the middle estimate sits 1.1-fold (0.03 log units) below what was measured, within the range that was stated.
By their numbers in this assay, from the lowest: compound 3; then compounds 1 and 4 (each within the scatter of the next); then compound 2.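

Placing the second methyl as in 1,5-dimethyl-1H-pyrazol-4-yl rather than 1,3-dimethyl-1H-pyrazol-4-yl gives no readable difference, a 1.4-fold higher number from compound 1 to compound 4 (0.16 log units; within the scatter), so among these two compounds the methyl's place on the pyrazole does not register in this measurement. Adding the group to the bare carbon of compound 3 costs about as much in this arrangement, a 3.9-fold higher number from compound 3 to compound 4 (0.59 log units; beyond the scatter), as the earlier arrangement did. Compound 4 also stays well clear of the trifluoromethyl compound, an 8.3-fold lower number from compound 2 to compound 4 (0.92 log units; beyond the scatter), so the large rise is not seen with a methyl at either place. Nothing measured here explains these differences. On these data alone, whether a smaller group on that aromatic carbon, such as a plain amine or a methylamino group, would keep the number near that of compound 3 remains open.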